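One More Methoxy on a Weak Growth Inhibitor

The source may hold more compounds than are shown below. What is called first, only, known or untested is meant among the compounds shown, and "the series" means these compounds.

In a functional assay on A2780 cells (Homo sapiens) for antiproliferative activity, read by MTT assay, with a stated time of 48 h (on this read-out lower numbers stand for stronger inhibition of growth and higher numbers for weaker inhibition of growth), compound 1 (`COC(=O)N1N=C(c2ccccc2)CC1c1ccc(OC)c(O)c1`) gives 4960 nM, while compound 2 (`COC(=O)N1N=C(c2ccccc2)CC1c1ccc(OC)c(OC)c1`) gives 29900 nM. Compound 2 therefore holds the higher of the two numbers and shows the weaker inhibition of growth. Compound 3 (`COC(=O)N1N=C(c2ccccc2)CC1c1cc(OC)c(OC)cc1OC`) has not yet been measured. It differs from compound 2 by methoxy in place of hydrogen on an aromatic carbon.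

Among the measured compounds shown here, only one measured step bears on this change, and only loosely. That step, a 6.0-fold higher number from compound 1 to compound 2 (0.78 log units; beyond the scatter), is modest and comes from methyl in place of hydrogen on an oxygen on an aromatic ring. For the measured compounds named here, this is a different kind of change from the one in compound 3. Going by the values given here, it shows that a small edit can move the number in this assay, but no measured pair adds a methoxy on an aromatic carbon, so the direction remains open. The estimated step, a 1.2-fold lower number from compound 2 to compound 3 (0.08 log units; within the scatter), is expected to be small, and its direction is uncertain. Compound 3 is expected at 25000 nM, with an estimated range from 8000 nM to 80000 nM.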

Compound 3, concentration for 50% growth inhibition: > 10000 nM
Compound 3: no number, only a limit (the forecaster's own chance of this, stated with the estimate: 15%); the middle value is on the limit's open side.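

In this assay compound 3 gives > 10000 nM as a limit of the assay and not a number. The step from compound 2 to compound 3 therefore cannot be read: the limit of > 10000 nM in this assay, at which 1 of the 3 values shown sits. The compounds shown leave open whether methoxy in place of hydrogen on an aromatic carbon moves the number at all, and in which direction.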